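A few compounds are considered here, and "the series" means these few. Any claim that something is new, unique, unknown or untested is made for them only; others in the source may bear on it.

Compound 1 `O=C(NC1CCCCC1)N1CCN(c2nc(-c3ccc4ccccc4n3)no2)CC1` carries a cyclohexyl group on its urea nitrogen, and in a functional assay on Shh Light II cells (Mus musculus) for inhibition, read by a luciferase reporter (on this read-out higher numbers stand for weaker inhibition and lower numbers for stronger inhibition), compound 1 gives 53 nM. Compound 2 `N#Cc1ccccc1NC(=O)N1CCC(c2nc(-c3ccc4ccccc4n3)no2)CC1` carries a 2-cyanophenyl group in that position, and in this assay compound 2 gives 190 nM. Going by the values given here, of the two numbers measured so far, the one for compound 2 is the higher, and the gap to compound 1 lies beyond the scatter of repeated measurements, so compound 2 is the weaker inhibitor of the pair; no single-point step connects them, since the two also differ in the ring that joins the urea to the shared core.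

Compound 3 `O=C(NC1CCCCC1)N1CCC(c2nc(-c3ccc4ccccc4n3)no2)CC1` has not yet been measured. It differs from compound 2 in one place (cyclohexyl in place of 2-cyanophenyl on an amide-type nitrogen). The step from compound 2 to compound 3 is expected to be a fall in the number, that is a gain in inhibition, of about a 2.7-fold lower number from compound 2 to compound 3 (0.43 log units; beyond the scatter), because compound 1 gives 53 nM with the same cyclohexyl group on the same kind of nitrogen. Compound 3 is therefore estimated at 70 nM, within a range from 25 nM to 250 nM.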

Compound 3, half-maximal inhibitory concentration: 57 nM
Compound 3: middle estimate off by 1.2-fold (0.09 log units), on the high side; the measured number falls inside the stated range.
By their numbers in this assay, from the lowest: compounds 1 and 3 (each within the scatter of the next); then compound 2.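

Going by these compounds alone, with the ring that joins the urea to the shared core held constant, placing cyclohexyl instead of 2-cyanophenyl on the amide-type nitrogen gives in this assay the first readable step, a 3.3-fold lower number from compound 2 to compound 3 (0.52 log units; beyond the scatter), a modest gain in inhibition beyond the scatter. The earlier pair could not show this, as compound 1 and compound 2 differ in two places; the group on this nitrogen now proves to change the number on its own. Compound 1 gives 53 nM and compound 3 gives 57 nM, two values within the scatter of each other, so for the cyclohexyl ureas the joining ring makes no difference that this read-out can resolve. Nothing measured here accounts for the step.

The compounds shown leave open whether the step follows the nitrile or the aromatic ring, as the two groups differ in both, and a plain phenyl group on the same nitrogen would separate the two. They also leave open how far the number holds for other groups there, such as cyclopentyl, tert-butyl or a longer chain like n-hexyl.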